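A few compounds are considered here, and "the series" means these few. Any claim that something is new, unique, unknown or untested is made for them only; others in the source may bear on it.

Going by the values given here, compound 2 `COc1cc2nc(/C=C/c3ccccc3F)nc(N3CCC(CCNS(N)(=O)=O)CC3)c2cc1OC` gives 211 nM in an assay on cells for inhibition of Ectonucleotide pyrophosphatase/phosphodiesterase family member 1 (Homo sapiens), with a stated time of 60 min (a lower number here means a stronger inhibitor, a higher number a weaker inhibitor), the higher of the two numbers measured so far; the other measured compound, compound 1 `COc1cc2nc(/C=C/c3ccccn3)nc(N3CCC(CCNS(N)(=O)=O)CC3)c2cc1OC`, gives 71 nM in this assay. Compound 3 `COc1cccc(/C=C/c2nc(N3CCC(CCNS(N)(=O)=O)CC3)c3cc(OC)c(OC)cc3n2)c1` has not yet been measured. It differs from compound 2 in one place: 3-methoxyphenyl in place of 2-fluorophenyl on a double-bonded chain carbon bound to a double-bonded chain carbon. Among the compounds with values here, the only measured step at this place is a 3.0-fold higher number from compound 1 to compound 2 (0.47 log units; beyond the scatter), which shows that a change of the aromatic ring on the double-bonded chain carbon shifted the number by a modest amount. Within the data shown here, no measured pair carries a methoxy on that ring, so the direction of the change cannot be read from the data; a step of comparable size in either direction, or none beyond the scatter, is equally plausible. Compound 3 is therefore expected to give about 200 nM in this assay, within a range of 70 nM to 600 nM. The expected step is a 1.1-fold lower number from compound 2 to compound 3 (0.02 log units; within the scatter), small and uncertain in sign.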

Compound 3, inhibition constant: 101 nM
For compound 3 the middle estimate is 2.0-fold (0.30 log units) above the measured one; low and high end bracket the measured number.
By their numbers in this assay, from the lowest: compounds 1 and 3 (each within the scatter of the next); then compound 2.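

In this assay, replacing 2-fluorophenyl with 3-methoxyphenyl gives a 2.1-fold lower number from compound 2 to compound 3 (0.32 log units; beyond the scatter) and so shows that a ring of carbon only at this place can also carry a lower number than compound 2, which pyridin-2-yl alone had shown before. Replacing pyridin-2-yl with 3-methoxyphenyl gives a 1.4-fold higher number from compound 1 to compound 3 (0.15 log units; within the scatter) and so shows that, among these compounds, pyridin-2-yl is not the only ring that reaches this range. Nothing measured here gives a reason for either step.

The change from compound 2 to compound 3 swaps both the group on the ring and its place, and the compounds shown do not separate the two. Also open, from the compounds shown here alone, is how the number responds to an unsubstituted phenyl, or to a phenyl carrying an amine or a carboxylic acid.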